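Furan for Hydroxyphenyl on the Hydrazone Carbon

The source may hold more compounds than are shown below. What is called first, only, known or untested is meant among the compounds shown, and "the series" means these compounds.

Among the compounds with values here, compound 3 `O=C(N/N=C/c1ccccc1O)c1cc(-c2ccc(Cl)cc2)nn1Cc1ccc(Cl)nc1` gives 500 nM in a physicochemical assay on A549 cells for solubility, read by microscopy, with a stated time of 24 h (on this read-out lower numbers stand for stronger inhibition and higher numbers for weaker inhibition), the higher of the two numbers known here; compound 1 `O=C(N/N=C/c1ccccc1O)c1cc(-c2ccccc2)nn1Cc1ccc(Cl)nc1` gives 440 nM in this assay, and a 1.1-fold higher number from compound 1 to compound 3 (0.06 log units; within the scatter). Compound 2 `COc1ccc(/C=N/NC(=O)c2cc(-c3ccccc3)nn2Cc2ccc(Cl)nc2)cc1` has "not determined" (no result reported) in this assay. Compound 4 `O=C(N/N=C/c1ccco1)c1cc(-c2ccc(Cl)cc2)nn1Cc1ccc(Cl)nc1` differs from compound 3 by furan-2-yl in place of 2-hydroxyphenyl on a carbon with a double bond to nitrogen. Within the data shown here, no measured step touches this part of the molecule: the only known step, from compound 1 to compound 3, concerns a chloro on a different ring and stayed within the scatter, so the direction of the present change cannot be read from the data, and the range must be wide. The expected value for compound 4 is 800 nM, with a range from 250 nM to 3000 nM, which means a 1.6-fold higher number from compound 3 to compound 4 (0.20 log units; within the scatter).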

Compound 4, half-maximal inhibitory concentration: 9820 nM
Compound 4: the middle estimate sits 12-fold (1.09 log units) below what was measured; the measured number lies above the stated range.
By their numbers in this assay, from the lowest: compounds 1 and 3 (each within the scatter of the next); then compound 4.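

Within the data shown here, replacing 2-hydroxyphenyl with furan-2-yl on a carbon with a double bond to nitrogen gives a 20-fold higher number from compound 3 to compound 4 (1.29 log units; beyond the scatter) in this assay, the first step beyond the scatter. The read-out therefore responds strongly to this position, whereas the chloro change, a 1.1-fold higher number from compound 1 to compound 3 (0.06 log units; within the scatter), stayed within the scatter.

The change removes the hydroxy group and alters the ring together, so the two remain inseparable; a plain phenyl or a thiophene-2-yl group on this carbon could tell them apart. Nothing available here accounts for the size of the step.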